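A few compounds are considered here, and "the series" means these few. Any claim that something is new, unique, unknown or untested is made for them only; others in the source may bear on it.

Working notes on the series. Going by the values given here, in a functional assay on SW-620 cells (Homo sapiens) for cytotoxicity, read by MTT assay, with stated times of 4 h and 72 h, tested at 2 uM (a higher number here means a weaker inhibitor, a lower number a stronger inhibitor), compound 1 `Cc1ccc(/C=C/C(=O)c2ccc(Nc3cc(C)nc4nc(SCc5nc6ccccc6[nH]5)nn34)cc2)cc1` gives 1520 nM, the highest of the three numbers so far, which makes it the weakest inhibitor measured. Compound 2 `Cc1cc(Nc2ccc(C(=O)/C=C/c3ccccc3)cc2)n2nc(SCc3nc4ccccc4[nH]3)nc2n1` gives 130 nM and compound 3 `Cc1cc(Nc2ccc(C(=O)/C=C/c3ccc(Cl)cc3)cc2)n2nc(SCc3nc4ccccc4[nH]3)nc2n1` gives 230 nM.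

The next entry is compound 4 `Cc1cc(Nc2ccc(C(=O)/C=C/c3ccc(-n4cccn4)cc3)cc2)n2nc(SCc3nc4ccccc4[nH]3)nc2n1`, and its difference from compound 1 is 1H-pyrazol-1-yl in place of methyl on an aromatic carbon. In words, this is 1H-pyrazol-1-yl in place of methyl on an aromatic carbon, para to a large group.

Two measured steps replace the same methyl. With hydrogen there is a 12-fold lower number from compound 1 to compound 2 (1.07 log units; beyond the scatter), a large step, and with chloro there is a 6.6-fold lower number from compound 1 to compound 3 (0.82 log units; beyond the scatter), a modest one. Both lie beyond the scatter and both lower the number. The remaining step, a 1.8-fold higher number from compound 2 to compound 3 (0.25 log units; within the scatter), lies within the scatter, so hydrogen and chloro are not separated here.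

Among the compounds with values here, none of the measured compounds carries a ring at this place, so these steps are only a loose guide. A step in the same direction is still expected in this assay, probably smaller than either measured one. The expected step is a 3.8-fold lower number from compound 1 to compound 4 (0.58 log units; beyond the scatter). The estimate for compound 4 is 400 nM, with an expected range from 130 nM to 1300 nM.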

Compound 4, half-maximal inhibitory concentration: 340 nM
For compound 4 the middle estimate is 1.2-fold (0.07 log units) above the measured one; low and high end bracket the measured number.
By their numbers in this assay, from the lowest: compounds 2, 3 and 4 (each within the scatter of the next, the first and the last beyond it); then compound 1.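

In this assay, the lower number seen with hydrogen and chloro also holds for a group carrying a ring, a 4.5-fold lower number from compound 1 to compound 4 (0.65 log units; beyond the scatter), so compound 1 now stands apart from all three other compounds and a five-membered aromatic ring at this place does not bring back the high number of the methyl compound. Going by these compounds alone, the new group is not separated from chloro, a 1.5-fold higher number from compound 3 to compound 4 (0.17 log units; within the scatter), but it is separated from hydrogen, a 2.6-fold higher number from compound 2 to compound 4 (0.42 log units; beyond the scatter), and this is the first step among the compounds without methyl at this place that lies beyond the scatter, although hydrogen and chloro themselves remain unseparated. Nothing shown gives a reason for any of these steps.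

Methyl is the only alkyl group here, so it remains open whether an ethyl group or a longer chain at this place would give a number like that of compound 1 or like those of the other three compounds. On these data alone, it is also open whether the ring nitrogens of 1H-pyrazol-1-yl matter, which a phenyl ring of carbon only would test, and how an amine or a carboxylic acid at this place would compare.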